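A few compounds are considered here, and "the series" means these few. Any claim that something is new, unique, unknown or untested is made for them only; others in the source may bear on it.

Compound 3 `O=C(Nc1ccnnc1)c1cc(N2CCC(O)CC2)ccc1OCc1ccccc1` stands second highest of the three compounds in a physicochemical assay for solubility, measured as kinetic solubility (on this read-out lower numbers stand for lower solubility and higher numbers for higher solubility), giving 28000 nM. Compound 1 `O=C(Nc1ccnnc1)c1cc(N2CCNCC2)ccc1OCc1ccccc1` gives 98000 nM, and compound 2 `O=C(Nc1ccnnc1)c1cc(N2CCC(F)CC2)ccc1OCc1ccccc1` gives 20000 nM. Replacing the piperazinyl produced a 4.9-fold lower number from compound 1 to compound 2 (0.69 log units; beyond the scatter) and a 3.5-fold lower number from compound 1 to compound 3 (0.54 log units; beyond the scatter), whereas the exchange of hydroxy for fluoro gave only a 1.4-fold higher number from compound 2 to compound 3 (0.15 log units; within the scatter). Compound 4 `O=C(Nc1ccnnc1)c1cc(N2C[C@H]3COC[C@H]3C2)ccc1OCc1ccccc1` differs from compound 3 by a group of 8 heavy atoms (6 carbon, 1 nitrogen, 1 oxygen; 2 five-membered non-aromatic rings with 1 hetero atom each) in place of a group of 7 heavy atoms (5 carbon, 1 nitrogen, 1 oxygen; one six-membered non-aromatic ring with 1 hetero atom), on an aromatic carbon. For the measured compounds named here, the one step that bears on it, a 1.4-fold higher number from compound 2 to compound 3 (0.15 log units; within the scatter), removed the hydrogen-bond donor without leaving the scatter, and the entering group of compound 4 likewise carries no donor. Compound 4 is therefore expected to show a step of a 1.4-fold lower number from compound 3 to compound 4 (0.15 log units; within the scatter), not beyond the scatter. Compound 4 is estimated at 20000 nM, in a range from 8000 nM to 50000 nM.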

Compound 4, solubility: 57000 nM
For compound 4 the middle estimate is 2.9-fold (0.45 log units) below the measured one, and the stated range ends below it.
By their numbers in this assay, from the lowest: compounds 2 and 3 (each within the scatter of the next); then compounds 4 and 1 (each within the scatter of the next).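

In this assay, the group with 2 five-membered non-aromatic rings moves the number beyond the scatter against both piperidine groups (a 2.0-fold higher number from compound 3 to compound 4 (0.31 log units; beyond the scatter); a 2.9-fold higher number from compound 2 to compound 4 (0.45 log units; beyond the scatter)). A group with 0 hydrogen-bond donors on this aromatic carbon therefore need not stay at the level of compound 2. Compound 4 also lies within the scatter of the piperazin-1-yl group (a 1.7-fold lower number from compound 1 to compound 4 (0.24 log units; within the scatter)).

No evidence is available to explain this change. As far as these compounds go, whether the ring oxygen, the two-ring shape or the stereocentres matter stays open, as does how a morpholin-4-yl group would stand here.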